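A few compounds are considered here, and "the series" means these few. Any claim that something is new, unique, unknown or untested is made for them only; others in the source may bear on it.

Compound 1 `COc1ccc2c(c1)NC(=O)CN2c1nc(NCCCO)nc2ccccc12`: 7.43 nM in a functional assay on MCF7 cells (Homo sapiens) for inhibition, read by sulforhodamine B assay, with a stated time of 48 h; a lower number here means a stronger inhibitor of growth, a higher number a weaker inhibitor of growth; compound 2 `CCOc1nc(N2CC(=O)Nc3cc(OC)ccc32)c2ccccc2n1`: 8.59 nM.

Compound 1 and compound 2 lie within the scatter of each other, the step being a 1.2-fold higher number from compound 1 to compound 2 (0.06 log units; within the scatter). Compound 3 `COc1ccc2c(c1)NC(=O)CN2c1nc(NC2CCCC2)nc2ccccc12` carries the change (cyclopentyl in place of 3-hydroxypropyl on a nitrogen on an aromatic ring). Among the measured compounds shown here, the only measured step at this position, a 1.2-fold higher number from compound 1 to compound 2 (0.06 log units; within the scatter), replaced the same group without a shift beyond the scatter, so a step of similar size is expected here: a 1.3-fold higher number from compound 1 to compound 3 (0.13 log units; within the scatter). Compound 3 is therefore estimated at 10 nM, with a range from 3 nM to 35 nM.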

Compound 3, concentration for 50% growth inhibition in the MCF7 assay: 7.67 nM
Compound 3: middle estimate off by 1.3-fold (0.12 log units), on the high side; the measured number falls inside the stated range.
By their numbers in the MCF7 assay, from the lowest: compounds 1, 3 and 2 (each within the scatter of the next).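

Replacing the 3-hydroxypropyl chain with a cyclopentyl ring leaves growth inhibition unchanged in the MCF7 assay (a 1.0-fold higher number from compound 1 to compound 3 (0.01 log units; within the scatter)), and cyclopentylamino matches ethoxy as well (a 1.1-fold lower number from compound 2 to compound 3 (0.05 log units; within the scatter)), so among these compounds this position accepts a ring without a hydroxyl. In a physicochemical assay for solubility, read by HPLC, at pH 7.4 (a higher number here means a more soluble compound, a lower number a less soluble compound), compound 1 gives 80.9 ug/mL and compound 3 gives 1.45 ug/mL. Among the compounds shown here, the change therefore costs solubility but not growth inhibition, which the earlier compounds could not show: the measured solubility of compound 1, 80.9 ug/mL, and of compound 3, 1.45 ug/mL, a 56-fold lower number (1.75 log units; beyond the scatter).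

Going by these compounds, whether a longer chain or an amine at this position would keep both the growth inhibition and the solubility remains open.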